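Moving the Hydroxyl Group: From Compound 3 to Compound 4

The source may report more compounds than this note shows. Statements on the series, on what has been measured and on what is new or still open speak of the compounds shown alone.

Of the compounds shown here, three sharing one fused core have been tested in a functional assay on HCT-15 cells (Homo sapiens) for cytotoxicity, read by CCK-8 assay and cell counting, with a stated time of 72 h; a lower number here means a stronger inhibitor, a higher number a weaker inhibitor. Compound 1 `COc1ccc(-c2cc3ccccc3c(-c3cccc(N)c3)n2)cc1` gives 2350 nM in this assay. Compound 2 `COc1ccc(-c2cc3cc(C)ccc3c(-c3cccc(N)c3)n2)c(C)c1` gives 2770 nM. Compound 3 `COc1ccc(-c2cc3cc(C)ccc3c(-c3cccc(O)c3)n2)cc1OC` gives 370 nM, the lowest of the three numbers; its gaps to compound 1 and to compound 2 both lie beyond the usual scatter, so compound 3 is the strongest inhibitor of the set.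

Compound 4 `COc1ccc(-c2cc3cc(C)ccc3c(-c3ccc(O)cc3)n2)cc1OC` has not yet been measured. It differs from compound 3 in a single place: 4-hydroxyphenyl in place of 3-hydroxyphenyl on an aromatic carbon. No pair of measured compounds differs in only one place, so the size of this kind of change has no direct precedent among the numbers shown, and the expectation rests on the change alone. A small step from compound 3 to compound 4 in this assay of about a 1.5-fold higher number from compound 3 to compound 4 (0.17 log units; within the scatter) is expected, leaning toward a weaker inhibitor but not clearly beyond the scatter. Compound 4 is therefore estimated at 550 nM, within a range from 180 nM to 1700 nM.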

Compound 4, half-maximal inhibitory concentration: 2520 nM
For compound 4 the middle estimate is 4.6-fold (0.66 log units) below the measured one; measured number above the stated range.
By their numbers in this assay, from the lowest: compound 3; then compounds 1, 4 and 2 (each within the scatter of the next).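

Moving the hydroxyl from 3-hydroxyphenyl to 4-hydroxyphenyl gives a 6.8-fold higher number from compound 3 to compound 4 (0.83 log units; beyond the scatter) in this assay, the first comparison in this set in which only one place changes. The two groups have the same atoms and the same counts of hydrogen-bond donors and acceptors, yet compound 4 is clearly the weaker inhibitor, so at this position on the ring next to the ring nitrogen, where the hydroxyl sits on the attached phenyl ring matters, not just whether it is present. No measurement available here bears on the reason for this loss of strength.

Going by these compounds, it remains open how a carboxylic acid or a fluorine atom would compare with the hydroxyl on this phenyl ring. On these data alone, it is also open whether the same shift of the hydroxyl would have a similar effect on the core of compound 1.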